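Swapping a Methyl for a Methoxy on a Potent Inhibitor

The source may hold more compounds than are shown below. What is called first, only, known or untested is meant among the compounds shown, and "the series" means these compounds.

Three compounds share one core and differ only in the group attached through the sulfur. Compound 1 `C#CCNC1CCc2c(SCCc3cccc(C)c3)cccc21` gives 0.35 nM in an assay on isolated protein for inhibition of Amine oxidase [flavin-containing] B (Homo sapiens) (a higher number here means a weaker inhibitor, a lower number a stronger inhibitor), the lowest of the three numbers. Compound 2 `C#CCNC1CCc2c(SCc3ccc(F)cc3F)cccc21` gives 2430 nM, and compound 3 `C#CCNC1CCc2c(SCc3ccc(Cl)cc3Cl)cccc21` gives 3760 nM; both stand far above compound 1, well beyond the scatter. Compound 4 `C#CCNC1CCc2c(SCCc3cccc(OC)c3)cccc21` is not yet measured. Compared with compound 1, it carries methoxy in place of methyl on an aromatic carbon. For the measured compounds named here, no measured pair shows this exact change, so its size is uncertain. Because compound 1 sits at 0.35 nM, only a modest loss in this assay is expected, a step of a 2.9-fold higher number from compound 1 to compound 4 (0.46 log units; beyond the scatter) that may stay within the scatter. Compound 4 is therefore estimated at 1 nM, between 0.2 nM and 6 nM.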

Compound 4, half-maximal inhibitory concentration: 28700 nM
Compound 4: middle estimate off by 29000-fold (4.46 log units), on the low side; measured number above the stated range.
By their numbers in this assay, from the lowest: compound 1; then compounds 2 and 3 (each within the scatter of the next); then compound 4.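

In this assay, methoxy in place of methyl on the aromatic carbon gives an 82000-fold higher number from compound 1 to compound 4 (4.91 log units; beyond the scatter), so going from one heavy atom to two at this place separates a very strong inhibitor from a very weak one. Compound 2 and compound 3 differ from compound 1 in more than one place and could not isolate this sensitivity. Nothing available explains the loss. The compounds shown leave open how a hydroxy, an ethyl or a chlorine would behave at this same place.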